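The source may hold more compounds than are shown below. What is called first, only, known or untested is meant among the compounds shown, and "the series" means these compounds.

Working notes on the series. Compound 1 `CC(C)Nc1nc(Nc2ccc(N3CCN(C)CC3)cc2)ncc1/N=C/c1cccs1` carries thiophen-2-yl on the carbon with a double bond to nitrogen and 4-methylpiperazin-1-yl on the aromatic ring. In a functional assay on HCT-116 cells (Homo sapiens) for antiproliferative activity, read by MTT assay (a lower number here means a stronger inhibitor, a higher number a weaker inhibitor), compound 1 gives only a limit, > 100000 nM. One of the three values shown sits at that floor (the limit of > 100000 nM in this assay, at which 1 of the 3 values shown sits). Compound 2 `CC(C)Nc1nc(Nc2ccc(N3CCN(C)CC3)cc2)ncc1/N=C/c1ccc(C(F)(F)F)cc1` differs from compound 1 by 4-(trifluoromethyl)phenyl in place of thiophen-2-yl on a carbon with a double bond to nitrogen; in this assay compound 2 gives 42200 nM, a step of an at least 2.3-fold lower number from compound 1 to compound 2 (0.37 log units; beyond the scatter). Compound 3 `CC(C)Nc1nc(Nc2ccc(S(N)(=O)=O)cc2)ncc1/N=C/c1cccs1` differs from compound 1 by sulfamoyl in place of 4-methylpiperazin-1-yl on an aromatic carbon; in this assay compound 3 gives 82100 nM, with an at least 1.2-fold lower number from compound 1 to compound 3 (0.08 log units; that floor lies within the scatter). The values of compound 2 and compound 3 lie within the scatter of each other. Compound 4 `CC(C)Nc1nc(Nc2ccc(S(N)(=O)=O)cc2)ncc1/N=C/c1ccc(C(F)(F)F)cc1` differs from compound 3 by 4-(trifluoromethyl)phenyl in place of thiophen-2-yl on a carbon with a double bond to nitrogen, the same change made from compound 1 to compound 2, at a place described in the same words, now on the core of compound 3. The earlier step is only a floor because compound 1 gave the limit > 100000 nM. Compound 4 is expected near 30000 nM. The expected step of a 2.7-fold lower number from compound 3 to compound 4 (0.44 log units; beyond the scatter) is set to match the earlier floor and allow a somewhat larger drop.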

Compound 4, half-maximal inhibitory concentration: > 100000 nM
Compound 4 gave a limit, no number (the forecaster's own chance of this, stated with the estimate: 8%); at least 3.3-fold (0.52 log units) between middle value and limit.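

In this assay compound 4 gives only a limit, > 100000 nM. Placing 4-(trifluoromethyl)phenyl in place of thiophen-2-yl therefore does not give the same result on the two cores, the new step being an at least 1.2-fold higher number from compound 3 to compound 4 (0.08 log units; that floor lies within the scatter): the same change on two cores in this assay, an at least 2.3-fold lower number (0.37 log units; beyond the scatter) from compound 1 to compound 2 and an at least 1.2-fold higher number (0.08 log units; that floor lies within the scatter) from compound 3 to compound 4, at least 2.8-fold (0.46 log units) apart, beyond the scatter of two such steps The sulfamoyl change also differs with the core, with an at least 2.3-fold higher number from compound 2 to compound 4 (0.37 log units; beyond the scatter), but these steps and the gaps between them are floors, so their true sizes remain unknown and the result gives no reason for the difference: the same change on two cores in this assay, an at least 1.2-fold lower number (0.08 log units; that floor lies within the scatter) from compound 1 to compound 3 and an at least 2.3-fold higher number (0.37 log units; beyond the scatter) from compound 2 to compound 4, at least 2.8-fold (0.46 log units) apart, beyond the scatter of two such steps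

On these data alone, whether an amine or a carboxylic acid on the phenyl ring, in place of trifluoromethyl, would behave like either group on the carbon with a double bond to nitrogen remains open. Any order among the compounds at the limit also remains open: the limit of > 100000 nM in this assay, at which 2 of the 4 values shown sit.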